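A few compounds are considered here, and "the series" means these few. Any claim that something is new, unique, unknown or untested is made for them only; others in the source may bear on it.

Measured so far:
- compound 1, `Cc1ccc(CN(C)CCCn2c(=O)oc3ccccc32)c(C)c1`: 1830 nM
- compound 2, `Cc1ccc(CN(C)CCCCn2c(=O)oc3ccccc32)cc1`: 97 nM
- compound 3, `Cc1ccc(CN2CCC(C(=O)Nc3ccccc3)CC2)cc1`: 105 nM

In an assay on membranes from liver for displacement of a labelled ligand from Sigma non-opioid intracellular receptor 1 (Rattus norvegicus), read by scintillation counting (a lower number here means a stronger inhibitor, a higher number a weaker inhibitor), compound 2 gives the lowest of the three numbers. Compound 3 lies nearest, within the usual scatter, so no order can be drawn between compound 2 and compound 3. For the measured compounds named here, compound 1 lies furthest, beyond the scatter, but it differs from compound 2 in more than one place and no single step connects the two; the two values alone show that compound 1 has a much higher number.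

Compound 4, `Cc1ccc(CN(C)CCCCn2c(=O)oc3ccccc32)c(C)c1`, is not yet measured. It differs from compound 2 by methyl in place of hydrogen on an aromatic carbon. Going by the values given here, no measured pair isolates this change, so the expectation rests on compound 2 alone. The expected step of a 1.6-fold higher number from compound 2 to compound 4 (0.22 log units; within the scatter) is small, if anything toward a higher number, and may well stay within the scatter. Compound 4 is therefore estimated at 160 nM, with a range from 50 nM to 500 nM.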

Compound 4, inhibition constant: 239 nM
The estimate for compound 4 lay 1.5-fold (0.17 log units) below the measured number; low and high end bracket the measured number.
By their numbers in this assay, from the lowest: compounds 2 and 3 (each within the scatter of the next); then compound 4; then compound 1.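

In this assay, for the compounds shown here, the change from 4-methylphenyl to 2,4-dimethylphenyl gives the first single-place step: a 2.5-fold higher number from compound 2 to compound 4 (0.39 log units; beyond the scatter). A methyl on this aromatic carbon, ortho to a large group, therefore has a modest but readable cost in this one matched pair, and compound 4 still gives a measurable 239 nM. No measurement shown explains the direction or size of this step.

Other groups on the same carbon, such as fluorine, chlorine or methoxy, remain open, so it cannot be said whether the step is particular to methyl. Also open, as far as these compounds go, are a phenyl without the 4-methyl group and whether the same methyl would produce a similar step on the core of compound 3.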